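Propyl side-chain ring change from compound 1

The source may hold more compounds than are shown below. What is called first, only, known or untested is meant among the compounds shown, and "the series" means these compounds.

Measured in a functional assay on K562 cells (Homo sapiens) for antiproliferative activity, read by MTT assay, with a stated time of 48 h; on this read-out lower numbers stand for stronger inhibition and higher numbers for weaker inhibition:
- compound 1 `Cn1cc(C2=C(c3nn(CCCn4cccc4)c4ncccc34)C(=O)NC2=O)c2ccccc21` gives 21600 nM
- compound 2 `Cn1cc(C2=C(c3nn(CCCn4ccnc4)c4ncccc34)C(=O)N(c3ccccc3)C2=O)c2ccccc21` gives 5510 nM

Compound 1 holds the higher of these two numbers, and compound 2 lies lower, beyond the scatter. Compound 3 `Cn1cc(C2=C(c3nn(CCCN4CCCCC4)c4ncccc34)C(=O)NC2=O)c2ccccc21` has not yet been measured in this assay. Relative to compound 1, it carries piperidin-1-yl in place of 1H-pyrrol-1-yl on a saturated chain carbon, three bonds along the chain from an aromatic nitrogen. Among the compounds with values here, no measured pair isolates this change. Compound 2 at 5510 nM differs from compound 1 in more than one place, so it shows only that lower numbers occur among these compounds. A moderate step towards a lower number, beyond the scatter but with wide uncertainty, is therefore expected. The estimated step is a 3.1-fold lower number from compound 1 to compound 3 (0.49 log units; beyond the scatter) in this assay. For compound 3 the expected value is 7000 nM with an estimated range of 1800 nM to 25000 nM for the measurement.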

Compound 3, half-maximal inhibitory concentration: 5960 nM
Compound 3: the middle estimate sits 1.2-fold (0.07 log units) above what was measured; low and high end bracket the measured number.
By their numbers in this assay, from the lowest: compounds 2 and 3 (each within the scatter of the next); then compound 1.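

In this assay, within the data shown here, 3-(piperidin-1-yl)propyl in place of 3-(1H-pyrrol-1-yl)propyl gives a 3.6-fold lower number from compound 1 to compound 3 (0.56 log units; beyond the scatter), the only single-place comparison so far. It shows that the ring on a saturated chain carbon, three bonds along the chain from an aromatic nitrogen, has a modest but real bearing on the antiproliferative read-out, with the rest of the structure held constant. Nothing available explains this step.

The change alters ring size and aromatic character together, so the two cannot be separated here; a pyrrolidin-1-yl group on the same propyl chain would address that. Also open, from the compounds shown here alone, are how an open-chain dimethylamino group or a longer butyl chain would fare, and whether the step carries over to compounds bearing the phenyl group of compound 2.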